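The source may hold more compounds than are shown below. What is called first, only, known or untested is meant among the compounds shown, and "the series" means these compounds.

Compound 1 `C/C(C#Cc1ccccc1)=N\N/C(N)=N/S(=O)(=O)c1cc(C)c(Cl)cc1SCc1cccc(C)c1`: 130000 nM
Compound 2 `Cc1cc(S(=O)(=O)/N=C(\N)N/N=C/C#Cc2ccccc2)c(SCc2ccccc2Cl)cc1Cl`: 15000 nM

Of the compounds shown here, two have been tested in a functional assay on MCF7 cells (Homo sapiens) for antiproliferative activity, read by MTT assay, with a stated time of 72 h; on this read-out higher numbers stand for weaker inhibition and lower numbers for stronger inhibition. Compound 1 gives 130000 nM, while compound 2 gives 15000 nM. Compound 1 thus stands at the higher of the two numbers, and its gap to compound 2 lies beyond the usual scatter of this kind of measurement. The two measured compounds differ in more than one place, so no single structural change can be tied to that gap.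

Compound 3 `C/C(C#Cc1ccccc1)=N\N/C(N)=N/S(=O)(=O)c1cc(C)c(Cl)cc1SCc1cccc2ccccc12` has not yet been measured. It differs from compound 1 by naphthalen-1-yl in place of 3-methylphenyl on a saturated chain carbon bound to a sulfur; cut one bond further out, a 3-methylbenzyl group gives way to a (naphthalen-1-yl)methyl group.

Within the data shown here, with no measured step to rest on, the step of a 1.9-fold lower number from compound 1 to compound 3 (0.27 log units; within the scatter) is expected to be small, toward lower numbers, and may well fall within the scatter. Compound 3 is therefore estimated at 70000 nM, with a range from 15000 nM to 250000 nM.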

Compound 3, half-maximal inhibitory concentration: 210000 nM
For compound 3 the middle estimate is 3.0-fold (0.48 log units) below the measured one; measured number inside the range.
By their numbers in this assay, from the lowest: compound 2; then compounds 1 and 3 (each within the scatter of the next).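

In this assay, placing naphthalen-1-yl in place of 3-methylphenyl on a saturated chain carbon bound to a sulfur gives a 1.6-fold higher number from compound 1 to compound 3 (0.21 log units; within the scatter). Among these compounds, this is the first change here that can be read at a single place, and it shows that going from one six-membered aromatic ring to 2 such rings at this position does not separate the two compounds on this read-out. No measurement shown here explains this result.

Still open, as far as these compounds go, is whether a different kind of group, such as a carboxylic acid, an amine or a simple longer chain in place of the 3-methylbenzyl group, would move the number beyond the scatter. Also open, from the compounds shown here alone, is whether the same change would give a similar step when the rest of the molecule differs from compound 1.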